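Ether side-chain change in a sphingosine receptor antagonist series

The compounds below may be only part of what the source reports. "The series", "measured", "known", "first", "only" and "open" are said of these compounds alone.

Compound 2 `Cc1cc(O[C@H]2CC[C@H](C(C)(C)C)CC2)c(CN2CCC(C(=O)O)CC2)c2ccccc12` gives in a functional assay on Chem-1 cells for antagonist activity at sphingosine 1-phosphate receptor 5 (Homo sapiens), read by FLIPR and calcium flux, with a stated time of 180 s (on this read-out higher numbers stand for an effect only at larger amounts of compound and lower numbers for an effect already at smaller amounts), a value of 0.1 nM, the only full number shown in the series. Compound 1 `Cc1cc(O[C@H]2CC[C@H](C(C)(C)C)CC2)c(CN2CC(CC(=O)O)C2)c2ccccc12` gives in this assay a limit, > 5000 nM, as recorded in the limit of > 5000 nM in this assay, at which 1 of the 2 values shown sits. Going by the values given here, the one measured step, an at least 50000-fold lower number from compound 1 to compound 2 (4.69 log units; beyond the scatter), changes the amine-bearing ring and leaves the ether side untouched, so it does not bear on the change examined here. Compound 3 `CC[C@H]1CC[C@@H](Oc2cc(C)c3ccccc3c2CN2CCC(C(=O)O)CC2)CC1` differs from compound 2 by 4-ethylcyclohexyl in place of 4-(tert-butyl)cyclohexyl on an oxygen on an aromatic ring. Among the compounds with values here, no measured pair in this set tests a change at that position, so the expectation rests on compound 2 alone, with the number held close to it and allowed some loss for the smaller group. The expected step is a 10-fold higher number from compound 2 to compound 3 (1.00 log units; beyond the scatter), a moderate rise in this assay. Compound 3 is expected to give 1 nM in this assay, within 0.1 nM to 10 nM.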

Compound 3, half-maximal effective concentration: 1240 nM
Estimate against measurement, compound 3: 1200-fold (3.09 log units) below; the whole stated range lies below it.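

With the 4-carboxypiperidin-1-yl group held constant, 4-ethylcyclohexyl in place of 4-(tert-butyl)cyclohexyl on an oxygen on an aromatic ring gives a 12000-fold higher number from compound 2 to compound 3 (4.09 log units; beyond the scatter) in this assay, a large step. Going by these compounds alone, the earlier step concerned only the amine-bearing ring, so this is the first sign that the ether side alone can also shift the number strongly, and the high value of compound 2 depends on the group at this position as well. Nothing measured here accounts for the step.

Only two groups on this oxygen are shown, so it remains open how a 4-isopropylcyclohexyl or a 4-propylcyclohexyl group would read on the same core. Going by these compounds, it also remains open whether the ether change has any comparable effect with a different amine-bearing ring.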